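The source may report more compounds than this note shows. Statements on the series, on what has been measured and on what is new or still open speak of the compounds shown alone.

The study concerns two measured compounds on a shared core and one still to be measured. Compound 1, `COc1cccc(/C=C2\CCC/C(=C\c3ccccc3Cl)C2=O)c1OC`, gives in a functional assay on SW-620 cells (Homo sapiens) for cytotoxicity, read by MTT assay, with a stated time of 72 h (on this read-out lower numbers stand for stronger inhibition and higher numbers for weaker inhibition), a value of 10300 nM. Compound 2, `COc1ccc(/C=C2\CCC/C(=C\c3ccccc3Br)C2=O)cc1OC`, gives in this assay a value of 5300 nM. Compound 2 thus holds the lowest of the two numbers shown, but its gap to compound 1 lies within the usual scatter of such measurements, so the two results cannot be told apart with any confidence.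

The next compound is compound 3, `COc1ccc(/C=C2\CCC/C(=C\c3ccc(Cl)cc3Cl)C2=O)cc1OC`. It differs from compound 2 in one place: 2,4-dichlorophenyl in place of 2-bromophenyl on a double-bonded chain carbon bound to a double-bonded ring carbon. Within the data shown here, no measured pair in this set isolates that kind of change, so nothing here tells how the read-out responds to it; the only guide is that both measured compounds sit within the scatter of one another.

The expected step of a 1.0-fold higher number from compound 2 to compound 3 (0.02 log units; within the scatter) is therefore small, with no direction preferred beyond the scatter. For compound 3 the estimate in this assay is 5500 nM, with a range from 2000 nM to 16000 nM.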

Compound 3, half-maximal inhibitory concentration: 10300 nM
For compound 3 the middle estimate is 1.9-fold (0.27 log units) below the measured one, and the stated range covers the measured number.
By their numbers in this assay, from the lowest: compounds 2, 1 and 3 (each within the scatter of the next).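

In this assay, among these compounds, the step of a 1.9-fold higher number from compound 2 to compound 3 (0.29 log units; within the scatter) is the first measured comparison in this set that isolates a single change on the shared core. It shows that, on a double-bonded chain carbon bound to a double-bonded ring carbon, 2,4-dichlorophenyl and 2-bromophenyl cannot be told apart by this read-out, and this one pair gives the change no direction. Nothing among the data shown explains this result.

The compounds shown leave open whether any group at this place could move the number beyond the scatter, as only halogen-bearing phenyl rings appear there, and a phenyl ring carrying a dimethylamino group or a carboxylic acid, or a pyridine ring, would probe a different kind of substituent. Among the compounds shown here, also open is whether the placing of the two methoxy groups matters on its own, as compound 1 and compound 2 differ in more than one place and no pair here separates that change.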